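The compounds below may be only part of what the source reports. "The series", "measured", "known", "first", "only" and "open" are said of these compounds alone.

The measured compounds, each in an ADME assay on Karpas-1106P cells (Homo sapiens) for cytotoxicity; on this read-out higher numbers stand for an effect only at larger amounts of compound and lower numbers for an effect already at smaller amounts:
Compound 1 `Cc1ccc(S(=O)(=O)N[C@@H](CC(=O)NC(C)(C)C)C(=O)NCCNC(=O)c2c(O)cccc2F)cc1`: in this assay compound 1 reaches only the limit > 11100 nM, not a number.
Compound 2 `Cc1ccc(S(=O)(=O)N[C@@H](CC(=O)NC(C)(C)C)C(=O)NCCNC(=O)c2cc(Cl)ccn2)cc1`: in this assay compound 2 also sits at the limit > 11100 nM.
Compound 3 `Cc1ccc(S(=O)(=O)N[C@@H](CC(=O)NC(C)(C)C)C(=O)NCCNC(=O)c2cccc(C(C)C)c2)cc1`: in this assay compound 3 likewise stops at the limit > 11100 nM.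

Compound 3 therefore stands where the other two stand, at the limit described by the limit of > 11100 nM in this assay, at which 3 of the 3 values shown sit, and none of the three values is a number. The step that the two limits leave unreadable from compound 1 to compound 2, the step that the two limits leave unreadable from compound 1 to compound 3 and the step that the two limits leave unreadable from compound 2 to compound 3 are all unreadable, since both ends of each lie at that limit. The compound not yet measured, compound 4 `C#Cc1cccc(C(=O)NCCNC(=O)[C@H](CC(=O)NC(C)(C)C)NS(=O)(=O)c2ccc(C)cc2)c1`, differs from compound 3 in one place: ethynyl in place of isopropyl on an aromatic carbon. Among the measured compounds shown here, no measured step bears directly on this exchange of ethynyl for isopropyl, and the three steps that are known give no size at all, so neither a direction nor a magnitude can be read from them. For the measured compounds named here, the only guide is the limit itself, at which every value sits. The step of a number no higher from compound 3 to compound 4 (the limit leaves the size open) is accordingly expected to be none beyond the scatter, with the result most likely again reported as a limit. Compound 4 is thus estimated at 11100 nM in this assay, with a range from 5000 nM to 30000 nM.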

Compound 4, half-maximal effective concentration: > 11100 nM
Compound 4: no number, only a limit; the forecaster's own chance of this, stated with the estimate: 85%; the middle value lies on the limit itself.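

In this assay, compound 4 ends like compound 1, compound 2 and compound 3 with a limit and not a number, so no step among these compounds can be read: the limit of > 11100 nM in this assay, at which 4 of the 4 values shown sit.

The compounds shown leave open at what concentration any of them would show an effect in this assay, and whether the groups exchanged among them differ at all.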